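From cyano to nitro: compound 2 and compound 3

The source may report more compounds than this note shows. Statements on the series, on what has been measured and on what is new or still open speak of the compounds shown alone.

Compound 1 `CC(O)(CSc1cc(C(F)(F)F)cc(C(F)(F)F)c1)C(=O)Nc1cccc(S(F)(F)(F)(F)F)c1` with 9400 nM
Compound 2 `CC(O)(CS(=O)(=O)c1ccc(S(F)(F)(F)(F)F)cc1)C(=O)Nc1ccc(C#N)cc1C(F)(F)F` with 25600 nM

Both compounds were tested in a functional assay on DU-145 cells (Homo sapiens) for antiproliferative activity, read by propidium iodide staining, with a stated time of 96 h (a higher number here means a weaker inhibitor, a lower number a stronger inhibitor), and reported as half-maximal inhibitory concentrations. Compound 1 gives 9400 nM and compound 2 gives 25600 nM. For the measured compounds named here, the gap between the two lies beyond the usual scatter, so compound 2 is the weaker inhibitor of the pair and holds the highest number so far. The two differ in more than one place, so no single change can be read from them.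

Compound 3 `CC(O)(CS(=O)(=O)c1ccc(S(F)(F)(F)(F)F)cc1)C(=O)Nc1ccc([N+](=O)[O-])cc1C(F)(F)F` departs from compound 2 in one place, with nitro in place of cyano on an aromatic carbon, meta to a trifluoromethyl group and para to a large group (nitro in place of cyano on an aromatic carbon). Going by the values given here, no measured pair shows this exchange, so the expectation rests on compound 2 at 25600 nM alone and remains rough. The step expected is a 1.2-fold lower number from compound 2 to compound 3 (0.07 log units; within the scatter) as estimated, which stays within the scatter. Compound 3 is estimated at 22000 nM and its expected range runs from 9000 nM to 50000 nM until the measurement is in.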

Compound 3, half-maximal inhibitory concentration: 17700 nM
Beside the measured number, compound 3's estimate is 1.2-fold (0.09 log units) above it, within the range that was stated.
By their numbers in this assay, from the lowest: compounds 1, 3 and 2 (each within the scatter of the next, the first and the last beyond it).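

In this assay, nitro in place of cyano on an aromatic carbon, meta to a trifluoromethyl group and para to a large group, gives a 1.4-fold lower number from compound 2 to compound 3 (0.16 log units; within the scatter) and so provides the first exchange among these compounds that can be read in one place. At this position, then, the number does not separate nitro from cyano, although the entering group has 3 heavy atoms in place of 2 and 2 hydrogen-bond acceptors in place of 1, and a double bond outside the aromatic ring replaces a triple bond. Nothing available explains this outcome.

The pair leaves open whether an amine, a carboxylic acid, a methyl group or a chlorine atom on this same aromatic carbon would also stay within the scatter of compound 2 and compound 3. It also leaves open whether nitro and cyano would remain this close on another core, since this single exchange has been read only on the core shared by compound 2 and compound 3.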